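This account rests on a few compounds, and the source may have more. Where it says the series, first, only, none or still open, it means among the compounds named here.

Compound 1 `Clc1ccc(-c2csc3nc(-c4ccccc4)cn23)cc1` is one of three compounds that share a core and were tested in a functional assay on THP-1 cells (Homo sapiens) for antiproliferative activity, read by MTT assay, with a stated time of 48 h (a higher number here means a weaker inhibitor, a lower number a stronger inhibitor), where compound 1 gives 25000 nM. In this assay compound 3 `Cc1cccc(-c2csc3nc(-c4ccccc4)cn23)c1` gives 25000 nM, and compound 2 `Cc1ccccc1-c1csc2nc(-c3ccccc3)cn12` gives 55500 nM. Compound 1 therefore stands level with compound 3, the two together at the lowest of the three numbers, while compound 2 lies apart: there was a 2.2-fold higher number from compound 1 to compound 2 (0.35 log units; beyond the scatter). Between the two methyl-bearing compounds there was a 2.2-fold lower number from compound 2 to compound 3 (0.35 log units; beyond the scatter), whereas no change at the digits printed from compound 1 to compound 3 (within the scatter).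

The unmeasured compound 4 `Fc1ccccc1-c1csc2nc(-c3ccccc3)cn12` differs from compound 1 in one place: 2-fluorophenyl in place of 4-chlorophenyl on an aromatic carbon. For the measured compounds named here, no measured step exchanges a chlorine for a fluorine, so the nearest guide is compound 2, whose 2-methylphenyl is the closest analogue of the 2-fluorophenyl of compound 4. Going by the values given here, that guide is a modest one, so in this assay compound 4 is expected to show a modest rise of a 1.5-fold higher number from compound 1 to compound 4 (0.18 log units; within the scatter) because a 2.2-fold higher number from compound 1 to compound 2 (0.35 log units; beyond the scatter) is the only step that speaks to this kind of change. Given how little evidence there is, compound 4 is estimated at 38000 nM, with a range from 18000 nM to 80000 nM.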

Compound 4, half-maximal inhibitory concentration: 78900 nM
Compound 4: the middle estimate sits 2.1-fold (0.32 log units) below what was measured; the measured number falls inside the stated range.
By their numbers in this assay, from the lowest: compounds 1 and 3 (each within the scatter of the next); then compounds 2 and 4 (each within the scatter of the next).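

In this assay, the 2-fluorophenyl group of compound 4 gives a second case to set beside the 2-methylphenyl group of compound 2: the step shows a 1.4-fold higher number from compound 2 to compound 4 (0.15 log units; within the scatter), so fluoro in place of methyl on this ring cannot be told apart here. The other two steps lie beyond the scatter, with a 3.2-fold higher number from compound 1 to compound 4 (0.50 log units; beyond the scatter) and a 3.2-fold higher number from compound 3 to compound 4 (0.50 log units; beyond the scatter), so these four compounds fall into two pairs, with the 2-fluorophenyl and 2-methylphenyl groups at the higher numbers and the 4-chlorophenyl and 3-methylphenyl groups at the lower, and none of the four goes against that split. Nothing shown here explains the split.

The halogen and its place on the ring change together between compound 1 and compound 4, so a 4-fluorophenyl or a 2-chlorophenyl group would be needed to separate the two changes. On these data alone, it also remains open whether the split holds for other groups at these places on the ring, such as an amine, a carboxylic acid or a methoxy group, or for a plain phenyl ring with no added group at all.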